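A few compounds are considered here, and "the series" means these few. Any claim that something is new, unique, unknown or untested is made for them only; others in the source may bear on it.

Two compounds of this series share one urea-linked core and differ only at an oxygen on an aromatic ring. In a functional assay on OVCAR-4 cells (Homo sapiens) for inhibition, read by sulforhodamine B assay, with a stated time of 48 h, tested at 1 uM (on this read-out lower numbers stand for a stronger effect and higher numbers for a weaker effect at the one concentration tested), compound 1 `O=C(Nc1cccc(-n2cc(-c3ccncc3)c(-c3cc(O)cc(Cl)c3)n2)c1)Nc1ccc(Cl)c(C(F)(F)F)c1` gives 105%, whereas compound 2 `COc1cc(Cl)cc(-c2nn(-c3cccc(NC(=O)Nc4ccc(Cl)c(C(F)(F)F)c4)c3)cc2-c2ccncc2)c1` gives 62% in this assay. Within the data shown here, the one measured step, a number 43 percentage points lower from compound 1 to compound 2 (beyond the scatter), therefore leaves compound 2 as the lower of the two numbers, its only neighbour being compound 1, a number beyond the scatter higher.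

Compound 3 `COc1cc(Cl)cc(-c2nn(-c3cccc(NC(=O)Nc4cccc(C(F)(F)F)c4)c3)cc2-c2ccncc2)c1` differs from compound 2 by hydrogen in place of chloro on an aromatic carbon: the 4-chloro-3-(trifluoromethyl)phenyl becomes a 3-(trifluoromethyl)phenyl. Among the measured compounds shown here, no measured step touches this part of the molecule; the single known step concerns the oxygen on the other aromatic ring and says nothing about the chloro. For the measured compounds named here, with no comparable step to lean on, the expectation for compound 3 is a step of about a number 13 percentage points higher from compound 2 to compound 3 (beyond the scatter) in this assay, a modest move toward a higher number that may well stay within the scatter. Compound 3 is accordingly estimated at 75% in this assay, with a range from 50% to 100%.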

Compound 3, a percentage reported as activity, at one concentration (the size of the read-out at that concentration, not a potency): 71%
Beside the measured number, compound 3's estimate is 4 percentage points above it; low and high end bracket the measured number.
By their numbers in this assay, from the lowest: compounds 2 and 3 (each within the scatter of the next); then compound 1.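

Hydrogen in place of chloro, on the aromatic carbon ortho to a trifluoromethyl group, gives a number 9 percentage points higher from compound 2 to compound 3 (within the scatter) in this assay, so this read-out does not separate compound 2 from compound 3. Among these compounds, the chloro of the 4-chloro-3-(trifluoromethyl)phenyl is therefore not required for the effect seen at the one concentration tested, whereas the change at the oxygen on the other aromatic ring gave a number 43 percentage points lower from compound 1 to compound 2 (beyond the scatter) and remains the only step here beyond the scatter. Nothing available accounts for how little this position responds to the change.

Going by these compounds, it remains open whether an amine, a carboxylic acid or a methoxy group on this same carbon would also stay within the scatter of compound 2 and compound 3, and whether the trifluoromethyl group that remains in both matters to the effect. On these data alone, it is equally open whether hydrogen in place of chloro would read the same way on the core of compound 1, or at concentrations other than the single one used here.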